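A few compounds are considered here, and "the series" means these few. Any claim that something is new, unique, unknown or untested is made for them only; others in the source may bear on it.

Compound 1 `Cc1cn2c(/C=N/Nc3ccccn3)c(-c3ccc(Cl)c([N+](=O)[O-])c3)nc2s1`: 7760 nM
Compound 2 `Cc1cn2c(/C=N/NC(=N)N)c(-c3ccsc3)nc2s1`: 6920 nM
Compound 3 `N=C(N)N/N=C/c1c(-c2cc(Cl)sc2Cl)nc2n1CCS2`: 8710 nM

In a functional assay on cells (Cancer cell lines, Homo sapiens) for inhibition (on this read-out lower numbers stand for stronger inhibition of growth and higher numbers for weaker inhibition of growth), compound 3 gives 8710 nM and stands within the scatter of both compound 1 and compound 2, so the three cannot be ranked. Compound 4 `Cc1cc(-c2nc3n(c2/C=N/NC(=N)N)CCS3)c(C)s1` has 2,5-dimethylthiophen-3-yl in place of 2,5-dichlorothiophen-3-yl on an aromatic carbon. For the measured compounds named here, no measured pair isolates this change. Going by the values given here, the only guide is that compound 2 at 6920 nM and compound 3 at 8710 nM remain within the scatter despite differing in structure. No step beyond the scatter is therefore expected in this assay. The estimated step is a 1.1-fold lower number from compound 3 to compound 4 (0.04 log units; within the scatter). For compound 4 the expected value is 8000 nM, with an estimated range of 3500 nM to 18000 nM.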

Compound 4, concentration for 50% growth inhibition: 18600 nM
Compound 4: the middle estimate sits 2.3-fold (0.37 log units) below what was measured; the measured number lies above the stated range.
By their numbers in this assay, from the lowest: compounds 2, 1 and 3 (each within the scatter of the next); then compound 4.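

In this assay, for the compounds shown here, the change gives a 2.1-fold higher number from compound 3 to compound 4 (0.33 log units; beyond the scatter), the first step between compounds differing in one place, so this aromatic carbon is not indifferent to its substituent. The step is modest, and the two groups match in heavy atoms and hydrogen-bond acceptors. No measurement at hand bears on its cause. A single pair leaves open whether this holds on other versions of the shared core. It also leaves open how the number would read with methoxy groups or amines on the thiophene.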